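The source may hold more compounds than are shown below. What is called first, only, known or untested is meant among the compounds shown, and "the series" means these compounds.

Measured compounds:
Compound 1, `Cc1ccc(NC(=O)Nc2nc(Nc3ccccc3)cc(Sc3c[nH]c4ccccc34)n2)cc1`, in a functional assay on A549 cells (Homo sapiens) for inhibition, with a stated time of 72 h (on this read-out higher numbers stand for weaker inhibition and lower numbers for stronger inhibition), gives 23500 nM.
Compound 2, `O=C(Nc1ccccc1)Nc1nc(Nc2ccccc2)cc(Sc2c[nH]c3ccccc23)n1`, in this assay gives > 50000 nM, which is a limit of the assay rather than a number.
Compound 3, `Cc1cc(Cl)ccc1NC(=O)Nc1nc(Nc2ccccc2)cc(Sc2c[nH]c3ccccc23)n1`, in this assay gives > 50000 nM, again a limit rather than a number.

Compound 2 thus stands at the edge of what the assay can report, as stated by the limit of > 50000 nM in this assay, at which 2 of the 3 values shown sit. Of the three compounds only compound 1 yields a number, and the steps of an at least 2.1-fold higher number from compound 1 to compound 2 (0.32 log units; beyond the scatter) and an at least 2.1-fold higher number from compound 1 to compound 3 (0.32 log units; beyond the scatter) both run up to the limit, while the step that the two limits leave unreadable from compound 2 to compound 3 runs between two limits and cannot be sized.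

Compound 4, `O=C(Nc1ccccc1)Nc1nc(Sc2c[nH]c3ccccc23)cc(N2CCN(c3ccccn3)CC2)n1`, differs from compound 2 in one place: 4-(pyridin-2-yl)piperazin-1-yl in place of anilino on an aromatic carbon. Going by the values given here, none of the measured steps touches this part of the shared core; all three change the aryl group on the urea nitrogen. So no measured step bears on this change, and the data give no guide to the size or direction of the step in this assay. The starting point is itself only a limit. Compound 4 is estimated at 30000 nM, within 5000 nM to 100000 nM. This estimate corresponds to an expected step of an at least 1.6-fold lower number from compound 2 to compound 4 (0.22 log units; that floor lies within the scatter).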

Compound 4, half-maximal inhibitory concentration: 30300 nM
The estimate for compound 4 lay 1.0-fold (0.00 log units) below the measured number, and the stated range covers the measured number.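

Going by these compounds alone, compound 4 is the first compound here changed away from the urea, on the aromatic carbon that holds the anilino group in compound 2. It shows that a larger group, 4-(pyridin-2-yl)piperazin-1-yl, can stand at this position with a number still readable in this assay, and the change gives an at least 1.6-fold lower number from compound 2 to compound 4 (0.21 log units; that floor lies within the scatter). That figure is only a floor, so the change could be small or considerably larger, and its true size stays hidden because one end of the step is a limit and not a number: the limit of > 50000 nM in this assay, at which 2 of the 4 values shown sit.

The compounds shown do not tell whether any shift at this position belongs to the piperazine ring, to the pyridine attached to it, or to the loss of the anilino group, so a morpholine or an unsubstituted piperazine in the same place would be informative. On these data alone, it also remains open whether the 4-methylphenyl group on the urea, which in compound 1 gives 23500 nM, would work together with 4-(pyridin-2-yl)piperazin-1-yl or would bring no further change.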